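Methyl in place of benzoyl on an amine nitrogen

This account rests on a few compounds, and the source may have more. Where it says the series, first, only, none or still open, it means among the compounds named here.

For the measured compounds named here, the series so far holds compound 1 (`O=C(NCc1ccc(F)cc1)c1nc(Br)c2cccnc2c1NCc1ccc(F)cc1`), compound 2 (`N[C@H]1CC[C@H](Nc2c(C(=O)NCc3ccc(F)cc3)nc(Br)c3cccnc23)CC1`) and compound 3 (`O=C(NCCCNc1c(C(=O)NCc2ccc(F)cc2)nc(Br)c2cccnc12)c1ccccc1`), all on a shared core. Going by the values given here, in a functional assay on MCF7 cells (Homo sapiens) for cytotoxicity, read by MTT assay, with a stated time of 72 h (a higher number here means a weaker inhibitor, a lower number a stronger inhibitor), compound 1 is recorded as "not determined" (no result reported), which leaves only two numbers. Compound 2 gives 2000 nM and compound 3 gives 2000 nM, so compound 3 stands level with compound 2 within the scatter. Compound 4 (`CNCCCNc1c(C(=O)NCc2ccc(F)cc2)nc(Br)c2cccnc12`) carries methyl in place of benzoyl on an amine nitrogen. Among the compounds with values here, no measured pair isolates this change. Within the data shown here, with only that level pair as a guide, no step beyond the scatter is expected in this assay, and no direction is favoured. The step expected is no change at the digits printed from compound 3 to compound 4 (within the scatter). For compound 4 the estimated value is 2000 nM, with an expected range of 700 nM to 6000 nM.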

Compound 4, half-maximal inhibitory concentration: > 10000 nM
Compound 4 ended at the assay's limit; the forecaster's own chance of this, stated with the estimate: 5%; at least 5.0-fold (0.69 log units) between middle value and limit.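

In this assay compound 4 reads > 10000 nM, a limit of the assay and not a number, and it alone sits there: the limit of > 10000 nM in this assay, at which 1 of the 4 values shown sits.

Methyl in place of benzoyl on an amine nitrogen gives an at least 5.0-fold higher number from compound 3 to compound 4 (0.69 log units; beyond the scatter), so this position responds to its group, which the level earlier values could not show. The same compound also separates from the cyclohexyl analogue, with 3-(methylamino)propyl in place of 4-aminocyclohexyl giving an at least 5.0-fold higher number from compound 2 to compound 4 (0.69 log units; beyond the scatter).

Going by these compounds, the true size of both steps stays open behind the limit. On these data alone, whether the carbonyl or the aromatic ring of benzoyl carries the difference also stays open; an acetyl group or a free amine on that nitrogen would separate the two.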